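The compounds below may be only part of what the source reports. "The series", "measured", "known", "first", "only" and "open" are said of these compounds alone.

Measured so far:
compound 1 `CNc1cccc(NC(=O)CN2N=C(c3ccccc3)c3ccccc3N(CC(=O)C(C)(C)C)C2=O)c1` — 21%
compound 2 `CN(C)c1cccc(NC(=O)CN2N=C(C3CCCCC3)c3ccccc3N(CC(=O)C(C)(C)C)C2=O)c1` — 16%

In an assay on PC-3 cells for binding affinity to Cholecystokinin receptor type A (Homo sapiens), tested at 10 uM (on this read-out lower numbers stand for less inhibition and higher numbers for more inhibition at the one concentration tested (going by the name of the read-out)), compound 1 gives 21%, the highest of the two numbers. Compound 2 gives 16%, which lies within the scatter of that value, so the two cannot be told apart. Compound 3 `CNc1cccc(NC(=O)CN2N=C(c3ccccn3)c3ccccc3N(CC(=O)C(C)(C)C)C2=O)c1` is not yet measured. It differs from compound 1 in one place: pyridin-2-yl in place of phenyl on a carbon with a double bond to nitrogen. Going by the values given here, no measured pair shows this change, so its effect on the read-out is unknown. Compound 3 is expected to give a step of a number 1 percentage points lower from compound 1 to compound 3 (within the scatter), none beyond the scatter. Compound 3 is thus estimated at 20%, with a range from 5% to 38%.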

Compound 3, a percentage reported as inhibition, at one concentration (the size of the read-out at that concentration, not a potency): 22%
Compound 3: the middle estimate sits 2 percentage points below what was measured; measured number inside the range.
By their numbers in this assay, from the lowest: compounds 2, 1 and 3 (each within the scatter of the next).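

In this assay, going by these compounds alone, the first single-place comparison at this carbon with a double bond to nitrogen gives a number 1 percentage points higher from compound 1 to compound 3 (within the scatter) for pyridin-2-yl in place of phenyl. Replacing a ring carbon with nitrogen and gaining a hydrogen-bond acceptor therefore leaves no readable difference in this one pair. No available measurement explains this result.

Still open, from the compounds shown here alone, is whether a carboxylic acid or an aminomethyl group on the phenyl ring at this carbon would move the number beyond the scatter. Pyridin-3-yl and pyridin-4-yl also remain open here.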